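The source may report more compounds than this note shows. Statements on the series, on what has been measured and on what is new or still open speak of the compounds shown alone.

In an ADME assay on liver for metabolic stability, with Liver microsome (Homo sapiens) as the target, read by LC-MS, using microsomes (on this read-out higher numbers stand for fast clearance and lower numbers for slow clearance), compound 1 `CC(C)(C)[C@@H](O)C(=O)N1[C@@H]2C[C@@H]2C[C@H]1C(=O)NCc1cc(Cl)ccc1-n1cnnn1` gives 54 mL.min-1.g-1, the second highest of the three numbers in hand. Compound 3 `O=C(NCc1cc(Cl)ccc1-n1cnnn1)[C@@H]1[C@H]2C[C@H]2CN1C(=O)[C@H](O)c1ccccc1` gives 61 mL.min-1.g-1, a value that sits within the scatter of compound 1. Among the measured compounds shown here, compound 2 `CC1(C[C@@H](O)C(=O)N2C[C@H]3C[C@H]3[C@H]2C(=O)NCc2cc(Cl)ccc2-n2cnnn2)CC1` gives 12 mL.min-1.g-1, the only number that lies beyond the scatter below compound 1. Compound 4 `O=C(NCc1cc(Cl)ccc1-n1cnnn1)[C@@H]1C[C@H]2C[C@H]2N1C(=O)[C@H](O)c1cccc(F)c1` has not yet been measured. Against compound 1 the change is 3-fluorophenyl in place of tert-butyl on a saturated chain carbon bound to a carbonyl carbon and an oxygen on a saturated carbon. With no measured step of this kind in the set, the expectation for compound 4 in this assay is a step no larger than the scatter, in either direction, estimated as a 1.0-fold higher number from compound 1 to compound 4 (0.01 log units; within the scatter). The estimated value for compound 4 is 55 mL.min-1.g-1, with a range from 30 mL.min-1.g-1 to 100 mL.min-1.g-1.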

Compound 4, intrinsic clearance in microsomes: 32 mL.min-1.g-1
Compound 4: middle estimate off by 1.7-fold (0.24 log units), on the high side, within the range that was stated.
By their numbers in this assay, from the lowest: compound 2; then compounds 4, 1 and 3 (each within the scatter of the next).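

In this assay, among the compounds shown here, 3-fluorophenyl in place of tert-butyl on a saturated chain carbon bound to a carbonyl carbon and an oxygen on a saturated carbon gives a 1.7-fold lower number from compound 1 to compound 4 (0.23 log units; within the scatter), the only step that can be read at one place. At this place, then, a six-membered aromatic ring is taken up in place of a group without a ring, and the read-out stays within the scatter. Nothing at hand bears on the cause of this step.

Going by these compounds, whether an amine or a carboxylic acid at this place would give a step beyond the scatter stays open. So does the part played by the fluorine of 3-fluorophenyl.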